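A few compounds are considered here, and "the series" means these few. Any claim that something is new, unique, unknown or untested is made for them only; others in the source may bear on it.

Compound 1 `Brc1cn2ccnc2c(-c2ccc3ncn(C4CCCCC4)c3c2)n1` carries a bromo group on an aromatic carbon of its shared core. Among the compounds with values here, in a functional assay on UACC-62 cells (Homo sapiens) for inhibition, read by sulforhodamine B assay, with a stated time of 48 h, tested at 10 uM (on this read-out lower numbers stand for less inhibition and higher numbers for more inhibition at the one concentration tested (going by the name of the read-out)), compound 1 gives 19.8%, the lowest of the two numbers measured so far. Compound 2 `Fc1ccc(-c2cn3ccnc3c(-c3ccc4ncn(C5CCCCC5)c4c3)n2)cc1` differs from compound 1 in one place, a 4-fluorophenyl in place of bromo on an aromatic carbon; in this assay compound 2 gives 31%, a step of a number 11.2 percentage points higher from compound 1 to compound 2 (beyond the scatter) that lies beyond the usual scatter and is modest in size.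

Compound 3 `Clc1ccc(-c2cn3ccnc3c(-c3ccc4ncn(C5CCCCC5)c4c3)n2)cc1` has not yet been measured. The change from compound 1 to compound 3 is 4-chlorophenyl in place of bromo on an aromatic carbon. Within the data shown here, only one measured step bears on it: the step from compound 1 to compound 2, where a 4-fluorophenyl replaced the same bromo group and inhibition rose modestly. A 4-chlorophenyl entering at the same place is expected to act much like that 4-fluorophenyl, so the step from compound 1 to compound 3 is expected to be upward and of similar size, about a number 12.2 percentage points higher from compound 1 to compound 3 (beyond the scatter). Compound 3 is therefore estimated to reach 32% in this assay, with a range from 15% to 50%.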

Compound 3, a percentage reported as inhibition, at one concentration (the size of the read-out at that concentration, not a potency): 30.5%
Compound 3: the middle estimate sits 1.5 percentage points above what was measured, and the stated range covers the measured number.
By their numbers in this assay, from the lowest: compound 1; then compounds 3 and 2 (each within the scatter of the next).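

Compound 3 shows that the rise seen with the 4-fluorophenyl is not tied to that one group: in this assay the 4-chlorophenyl in place of bromo also gives a higher number, with a number 10.7 percentage points higher from compound 1 to compound 3 (beyond the scatter) as the step, so two compounds now support a gain over the bromo compound at this position. The comparison between the two phenyl compounds adds something the earlier pair could not show, since a number 0.5 percentage points lower from compound 2 to compound 3 (within the scatter) stays within the scatter and this read-out therefore does not separate chloro from fluoro on the phenyl ring. No measurement offered here accounts for these numbers, whether for the gain over bromo or for the lack of a difference between chloro and fluoro.

The three compounds leave open whether the phenyl ring alone carries the gain or the halogen on it is also needed, a question that a plain phenyl would address, and whether an amine or a carboxylic acid on that ring would move the number in either direction. They also leave open how these compounds would compare as potencies, as each number comes from a single concentration.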